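Ethoxy to Benzyloxy: Expected Lipophilicity of Compound 3

The compounds below may be only part of what the source reports. "The series", "measured", "known", "first", "only" and "open" are said of these compounds alone.

Compound 1, `Cc1cc(C)cc(NC(=O)COc2cc(C)nc3ccccc23)c1`: 5.39
Compound 2, `CCOc1ccc2nc(C)cc(OCC(=O)Nc3cc(C)cc(C)c3)c2c1`: 5.98

In a physicochemical assay for lipophilicity, read by HPLC, in phosphate buffer, measured as chromatographic lipophilicity, at pH 7.4 (on this read-out higher numbers stand for higher lipophilicity and lower numbers for lower lipophilicity), compound 1 gives 5.39 and compound 2 gives 5.98, the higher of the two numbers. For the measured compounds named here, the single measured step, a number 0.59 log units higher from compound 1 to compound 2 (beyond the scatter), came from ethoxy in place of hydrogen on an aromatic carbon. Compound 3, `Cc1cc(C)cc(NC(=O)COc2cc(C)nc3ccc(OCc4ccccc4)cc23)c1`, has not yet been measured in this assay. It differs from compound 2 by phenyl in place of methyl on a saturated chain carbon bound to an oxygen on an aromatic ring, which enlarges the very ethoxy group that the measured step introduced, so a rise at least as large is expected. Compound 3 is expected to give 6.9, within 6.4 to 7.5. The expected step is a number 0.92 log units higher from compound 2 to compound 3 (beyond the scatter).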

Compound 3, distribution coefficient: 7.03
Compound 3: the middle estimate sits 0.13 log units below what was measured, and the stated range covers the measured number.
By their numbers in this assay, from the lowest: compound 1; then compound 2; then compound 3.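

In this assay, replacing the methyl of the ethoxy group with phenyl gives a number 1.05 log units higher from compound 2 to compound 3 (beyond the scatter), so the number at this position had not stopped rising at ethoxy. Measured against plain hydrogen, benzyloxy gives a number 1.64 log units higher from compound 1 to compound 3 (beyond the scatter), and the three compounds climb in the order hydrogen, ethoxy, benzyloxy, with none going against that order. Nothing available explains the size of either step.

As far as these compounds go, whether a longer chain such as butoxy would land nearer ethoxy or benzyloxy remains open. So does what an amine or a carboxylic acid at this position would do to the number.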